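Chloro on the benzyl ring: a small step expected

The source may report more compounds than this note shows. Statements on the series, on what has been measured and on what is new or still open speak of the compounds shown alone.

The set rests on one shared core. Compound 1 `CC1=C(C(=O)Nc2ccc(Br)cc2)C(c2ccc(Cl)cc2Cl)N=C(SCc2ccccc2)N1` gives 1.5% in a functional assay on the whole organism (artery, strain albino) with Rattus norvegicus as the target, with a stated time of 15 min, at a dose of 10 mg/kg by the oral route; on this read-out higher numbers stand for more inhibition at the one dose given (going by the name of the read-out) and lower numbers for less inhibition. Compound 2 `CC1=C(C(=O)Nc2ccc(Br)cc2)C(c2ccc(Cl)cc2Cl)N=C(SCc2ccccc2Cl)N1` gives 3.1%, and compound 3 `COc1ccc(C2N=C(SCc3ccccc3)NC(C)=C2C(=O)Nc2ccc(Br)cc2)cc1` gives 1%, the lowest of the three numbers, though its gaps to compound 1 and compound 2 stay within the scatter. Compound 4 `COc1ccc(C2N=C(SCc3ccccc3Cl)NC(C)=C2C(=O)Nc2ccc(Br)cc2)cc1` is the unmeasured partner of compound 3; the change is chloro in place of hydrogen on an aromatic carbon. Among the compounds with values here, the one measured step of the same kind, a number 1.6 percentage points higher from compound 1 to compound 2 (within the scatter), stayed within the scatter, so no step beyond the scatter is expected here, with a number 1.5 percentage points higher from compound 3 to compound 4 (within the scatter) as the expected change. Compound 4 is therefore estimated at 2.5%, with a range from -5% to 10%.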

Compound 4, a percentage reported as inhibition, in the whole organism at one dose (the size of the read-out at that dose, not a potency): 3.1%
Beside the measured number, compound 4's estimate is 0.6 percentage points below it; measured number inside the range.
By their numbers in this assay, from the lowest: compounds 3, 1, 2 and 4 (each within the scatter of the next).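

Chloro in place of hydrogen on an aromatic carbon now has a second reading in this assay, a number 2.1 percentage points higher from compound 3 to compound 4 (within the scatter), so the step stays small with 4-methoxyphenyl as with 2,4-dichlorophenyl on the saturated ring carbon: the same change on two cores in this assay, a number 1.6 percentage points higher (within the scatter) from compound 1 to compound 2 and a number 2.1 percentage points higher (within the scatter) from compound 3 to compound 4, 0.5 percentage points apart, within the scatter of two such steps. The change from 2,4-dichlorophenyl to 4-methoxyphenyl also gains a second reading, no change at the digits printed from compound 2 to compound 4 (within the scatter), and it too stays small with either benzyl or 2-chlorobenzyl: the same change on two cores in this assay, a number 0.5 percentage points lower (within the scatter) from compound 1 to compound 3 and no change at the digits printed (within the scatter) from compound 2 to compound 4, 0.5 percentage points apart, within the scatter of two such steps. Going by these compounds, whether an amine or a carboxylic acid on that aromatic ring, or a longer chain in place of benzyl, would lift the number beyond the scatter stays open.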